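Acetyl at the meta position of an aziridine-carbonyl urea

The compounds below may be only part of what the source reports. "The series", "measured", "known", "first", "only" and "open" are said of these compounds alone.

Compound 1 `N#CC1CN1C(=O)Nc1ccc([N+](=O)[O-])cc1` gives 3900 nM in a functional assay on A549 cells (Homo sapiens) for inhibition; a lower number here means a stronger inhibitor, a higher number a weaker inhibitor. Compound 2 `N#CC1CN1C(=O)Nc1ccccc1` gives 9000 nM in this assay. Compound 3 `N#CC1CN1C(=O)Nc1ccc(S(N)(=O)=O)cc1` reaches only the limit > 38000 nM in this assay.

Among the two actual numbers, compound 2 holds the higher one, weaker than compound 1 by a 2.3-fold higher number from compound 1 to compound 2 (0.36 log units; beyond the scatter). Compound 4 `CC(=O)c1cccc(NC(=O)N2CC2C#N)c1` differs from compound 2 by acetyl in place of hydrogen on an aromatic carbon. Among the compounds with values here, two measured steps bear on this: removing the nitro group gave a 2.3-fold higher number from compound 1 to compound 2 (0.36 log units; beyond the scatter), whereas adding sulfamoyl gave an at least 4.2-fold higher number from compound 2 to compound 3 (0.62 log units; beyond the scatter), counted against the limit (the limit of > 38000 nM in this assay, at which 1 of the 3 values shown sits). So an added group has cut both ways on this core, and the acetyl case is open. For compound 4 the expected step is a 1.3-fold lower number from compound 2 to compound 4 (0.11 log units; within the scatter), estimated at 7000 nM with a range of 2500 nM to 25000 nM.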

Compound 4, half-maximal inhibitory concentration: 5600 nM
Estimate against measurement, compound 4: 1.3-fold (0.10 log units) above; the measured number falls inside the stated range.
By their numbers in this assay, from the lowest: compounds 1, 4 and 2 (each within the scatter of the next, the first and the last beyond it). At a limit, above all of these: compound 3.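

In this assay, acetyl in place of hydrogen gives a 1.6-fold lower number from compound 2 to compound 4 (0.21 log units; within the scatter), so this change on an aromatic carbon, meta to a group of 8 heavy atoms, cannot be separated from the scatter. Within the data shown here, the nitro and sulfamoyl steps on this core both lay beyond the scatter, which makes acetyl the first added group here with no readable effect. Nothing measured here explains this result.

An amine or a carboxylic acid at this position could behave differently, and so could a longer chain in place of acetyl. Going by these compounds, how acetyl behaves at other positions on the ring also stays open.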